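Swapping trifluoromethoxy for trifluoromethyl on a weak binder

The source may hold more compounds than are shown below. What is called first, only, known or untested is meant among the compounds shown, and "the series" means these compounds.

Measured compounds:
- compound 1, `CCOC(=O)C1=C(c2ccc3ccccc3c2)CCNC1`, in an assay on COS-1 cells for displacement of a labelled ligand from sodium-dependent dopamine transporter (Homo sapiens) (on this read-out lower numbers stand for stronger inhibition and higher numbers for weaker inhibition), gives 79 nM
- compound 2, `COC(=O)C1=C(c2ccc(S(C)(=O)=O)cc2)CCC1`, in this assay gives "not determined" (no result reported), that is, no number was reported for it
- compound 3, `COC(=O)C1=C(c2ccc(OC(F)(F)F)cc2)CCCC1`, in this assay gives 1660000 nM

Of the two compounds with a number, compound 3 has the higher one by a wide margin, and the gap between compound 3 and compound 1 lies far beyond the usual scatter of repeated measurements. Compound 1 and compound 3 also differ in several places at once, so that gap cannot be traced to any single change.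

Compound 4, `COC(=O)C1=C(c2ccc(C(F)(F)F)cc2)CCCC1`, has not yet been measured. It differs from compound 3 in one place: trifluoromethyl in place of trifluoromethoxy on an aromatic carbon. Among the compounds with values here, no pair of measured compounds shows this particular change, so there is no measured step to lean on. With compound 3 already so weak in this assay, the expectation is a step that is small or none beyond the scatter, in either direction.

For compound 4 in this assay the estimate is 1200000 nM, with a range from 250000 nM to 6000000 nM. This estimate means an expected step of a 1.4-fold lower number from compound 3 to compound 4 (0.14 log units; within the scatter), which amounts to little beyond the scatter.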

Compound 4, inhibition constant: 590000 nM
Compound 4: the middle estimate sits 2.0-fold (0.31 log units) above what was measured; low and high end bracket the measured number.
By their numbers in this assay, from the lowest: compound 1; then compound 4; then compound 3.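

Within the data shown here, putting trifluoromethyl in place of trifluoromethoxy, on an aromatic carbon para to a large group, gives a 2.8-fold lower number from compound 3 to compound 4 (0.45 log units; beyond the scatter) in this assay and provides the first comparison here in which only one place changes. The earlier compounds shown here differed in several places at once, so they could not show that this position responds to a change of group, even on a core that binds this weakly; the step is modest, and both compounds remain weak binders. What the swap does show is a difference in the result between two closely related fluorinated groups, but no measurement shown here says what lies behind this step.

The compounds shown leave open whether an amine, a carboxylic acid or a simple methyl group at the same place would lower the number further, leave it unchanged or raise it. They also leave open whether the same swap would give a step of similar size on a stronger binder, such as one built on the core of compound 1.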